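The source may report more compounds than this note shows. Statements on the series, on what has been measured and on what is new or still open speak of the compounds shown alone.

Measured compounds:
Compound 1, `CCCCNc1cncc(C(=O)NCc2ccccc2)n1`, gives 100000 nM
Compound 2, `O=C(NCc1ccccc1)c1cnc(Cl)cn1`, gives "not determined" (no result reported)

Two compounds share a core, and only one of them carries a number. In an ADME assay on MDCK cells (Canis lupus familiaris) for cytotoxicity, read by microscopy, with a stated time of 6 days (on this read-out higher numbers stand for lower toxicity in this test and lower numbers for higher toxicity in this test), compound 1 gives 100000 nM. Going by the values given here, compound 1 therefore stands as the only point of reference here: there is one further entry, compound 2, for which no result was reported, so no step between measured compounds can be drawn and nothing can be said about how the core responds to any change.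

Compound 3, `CCCCCCCNc1cncc(C(=O)NCc2ccccc2)n1`, differs from compound 1 in one place: propyl in place of hydrogen on a saturated chain carbon, four bonds along the chain from a nitrogen on an aromatic ring. Among the compounds with values here, no measured pair shows what a change of this kind does in this assay, so the expectation rests only on the single value of compound 1. The step from compound 1 to compound 3 is expected to stay close to the scatter, with a modest lean toward a lower number, and this expected step is a 1.7-fold lower number from compound 1 to compound 3 (0.22 log units; within the scatter). On that basis compound 3 is estimated at 60000 nM, within a range from 20000 nM to 150000 nM.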

Compound 3, minimum cytotoxic concentration: 4000 nM
Compound 3: middle estimate off by 15-fold (1.18 log units), on the high side; the measured number lies below the stated range.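

In this assay, putting propyl in place of hydrogen on a saturated chain carbon, four bonds along the chain from a nitrogen on an aromatic ring, brings a 25-fold lower number from compound 1 to compound 3 (1.40 log units; beyond the scatter), a step large enough to mean higher toxicity in this test rather than ordinary variation between repeats. Going by these compounds alone, this is the first sign that the shared core is sensitive to a change at this position, since compound 1 alone offered no comparison. The entering group adds only carbon, with no ring, no hydrogen-bond donor or acceptor and no net charge, yet no measurement at hand says why the step is this large.

With only two numbers on this core, the compounds shown leave open whether the value falls gradually as the chain grows or drops sharply at one particular length. A longer chain, or a chain of similar reach ending in an amine or a carboxylic acid, would show whether chain length alone tracks with the toxicity seen in this test.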